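Thiophene-fused aminopyrimidines: swapping the pendant heteroaryl

The compounds below may be only part of what the source reports. "The series", "measured", "known", "first", "only" and "open" are said of these compounds alone.

Compound 1 `N#Cc1ccc(-c2nc(N)c3cc(Cc4ccccc4)sc3n2)o1`: 3160 nM
Compound 2 `Nc1nc(-c2ccccn2)nc2sc(Cc3ccccc3)cc12`: 3710 nM
Compound 3 `Nc1nc(-c2ncccn2)nc2sc(Cc3ccccc3)cc12`: 618 nM

All three were run in a functional assay on CHO-K1 cells for antagonist activity at adenosine receptor A1 (Homo sapiens), read by a beta-galactosidase reporter and cAMP accumulation, with stated times of 15 min and 6 h; a lower number here means a stronger inhibitor, a higher number a weaker inhibitor. Compound 3 gives the lowest number of the three; the step of a 5.1-fold lower number from compound 1 to compound 3 (0.71 log units; beyond the scatter) and the step of a 6.0-fold lower number from compound 2 to compound 3 (0.78 log units; beyond the scatter) both lie beyond the scatter, while a 1.2-fold higher number from compound 1 to compound 2 (0.07 log units; within the scatter) does not.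

Compound 4 `N#Cc1cccc(-c2nc(N)c3cc(Cc4ccccc4)sc3n2)n1` differs from compound 3 by 6-cyanopyridin-2-yl in place of pyrimidin-2-yl on an aromatic carbon. The nearest comparison is compound 2, whose pyridin-2-yl lacks only the nitrile of the entering group; the step of a 6.0-fold lower number from compound 2 to compound 3 (0.78 log units; beyond the scatter) shows that a pyrimidin-2-yl gave a lower number than a pyridin-2-yl. Within the data shown here, no measured pair shows what the nitrile adds on this ring. Compound 4 is therefore expected to fall between compound 2 and compound 3, with a step of a 3.2-fold higher number from compound 3 to compound 4 (0.51 log units; beyond the scatter). The estimate for compound 4 is 2000 nM, range 500 nM to 8000 nM.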

Compound 4, inhibition constant: > 1000 nM
Compound 4: only a limit was reported; the forecaster's own chance of this, stated with the estimate: 5%; the middle value does not contradict the limit.
By their numbers in this assay, from the lowest: compound 3; then compounds 1 and 2 (each within the scatter of the next).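

Compound 4 carries only a limit of the assay in this assay, > 1000 nM. Relative to the pyrimidin-2-yl, the 6-cyanopyridin-2-yl at this carbon between two ring nitrogen atoms gives an at least 1.6-fold higher number from compound 3 to compound 4 (0.20 log units; that floor lies within the scatter), so the limit does not settle whether the change moves the number beyond the scatter. The steps from compound 1 and compound 2 to compound 4 cannot be read, so the effect of cyano in place of hydrogen stays unresolved. Open, going by these compounds, is how an amine or a carboxylic acid on the pyrimidin-2-yl ring would compare with compound 3.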